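The source may hold more compounds than are shown below. What is called first, only, known or untested is meant among the compounds shown, and "the series" means these compounds.

Compounds measured so far:
compound 1 `CCCCCCCCCCCCCCCCCCNC(=O)[C@H]1CSC(C2CCCCC2)N1` — > 20000 nM
compound 2 `CCCCCCCCCCCCCCCCCCNC(=O)[C@H]1CSC(c2cccc(O)c2)N1` — 31000 nM

In a functional assay on RH7777 cells (Homo sapiens) for antiproliferative activity against RH7777 (Rattus norvegicus), read by sulforhodamine B assay (on this read-out lower numbers stand for stronger inhibition and higher numbers for weaker inhibition), compound 1 gives > 20000 nM, which is a limit of the assay rather than a number. Compound 2 gives 31000 nM. The step that the limit leaves unreadable from compound 1 to compound 2 cannot be sized because compound 1 sits at the limit of > 20000 nM in this assay, at which 1 of the 2 values shown sits. Compound 3 `CCCCCCCCCCCCCCCCCCNC(=O)[C@H]1CSC(c2ccc([N+](=O)[O-])cc2)N1` differs from compound 1 by 4-nitrophenyl in place of cyclohexyl on a saturated ring carbon. No readable step bears on this change; compound 2, with a different aromatic group at the same place, stays weak, so compound 3 is estimated at 30000 nM (range 10000 nM to 90000 nM), a step that the limit leaves unreadable from compound 1 to compound 3 that is expected to remain within the scatter.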

Compound 3, half-maximal inhibitory concentration: about 20000 nM
Compound 3: middle estimate off by 1.5-fold (0.18 log units), on the high side; the range from low to high includes it.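

In this assay, 4-nitrophenyl in place of 3-hydroxyphenyl gives a 1.6-fold lower number from compound 2 to compound 3 (0.19 log units; within the scatter), so two different aromatic groups at this saturated ring carbon read alike, even though 4-nitrophenyl brings 2 hydrogen-bond acceptors and no hydrogen-bond donors. 4-Nitrophenyl in place of cyclohexyl gives a number no higher from compound 1 to compound 3 (the limit leaves the size open). The steps from compound 1 to these aromatic compounds cannot be read, leaving any comparison with cyclohexyl open: the limit of > 20000 nM in this assay, at which 1 of the 3 values shown sits.

On these data alone, what an aminophenyl or a carboxyphenyl group would give at this place stays open. So does whether any group here can move the number beyond the scatter.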